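The source may hold more compounds than are shown below. What is called first, only, known or untested is meant among the compounds shown, and "the series" means these compounds.

Measured so far in a functional assay on LNCaP cells (Homo sapiens) for antiproliferative activity; a lower number here means a stronger inhibitor, a higher number a weaker inhibitor
Compound 1 `Cn1ncc(Cl)c1-c1cc(C(=O)N[C@@H]2CN[C@H](CC(O)CO)C[C@H]2c2ccc(F)c(F)c2)oc1Cl` gives 100 nM
Compound 2 `Cn1ncc(Cl)c1-c1cc(C(=O)N[C@@H]2CN[C@H](CC(O)CO)C[C@H]2c2ccc(Cl)c(Cl)c2)oc1Cl` gives 70 nM
Compound 3 `Cn1ncc(Cl)c1-c1cc(C(=O)N[C@@H]2CN[C@H](CC(N)=O)C[C@H]2c2ccc(Cl)c(Cl)c2)oc1Cl` gives 160 nM

Compound 1 at 100 nM lies within the usual scatter of both compound 2 and compound 3, so it cannot be ranked against either one. Compound 4 `CNC(=O)C[C@@H]1C[C@@H](c2ccc(F)c(F)c2)[C@H](NC(=O)c2cc(-c3c(Cl)cnn3C)c(Cl)o2)CN1` has not been measured yet. Its change from compound 1 is methylcarbamoyl in place of 1,2-dihydroxyethyl on a saturated chain carbon bound to a saturated ring carbon and this means methylcarbamoyl in place of 1,2-dihydroxyethyl on a saturated chain carbon bound to a saturated ring carbon.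

For the measured compounds named here, no measured compound carries methylcarbamoyl. The closest guide is compound 3, which has carbamoyl at that place, and the matching swap gave a 2.3-fold higher number from compound 2 to compound 3 (0.36 log units; beyond the scatter) as a modest step beyond the scatter. That swap was made with 3,4-dichlorophenyl, whereas compound 4 keeps 3,4-difluorophenyl. Exchanging these two groups gave a 1.4-fold lower number from compound 1 to compound 2 (0.15 log units; within the scatter) and stayed within the scatter, so the carbamoyl step may well carry over. Going by these compounds, a similar modest rise in this assay is therefore expected, though with added uncertainty, since methylcarbamoyl itself is untested. The expected change is a 2.0-fold higher number from compound 1 to compound 4 (0.30 log units; within the scatter) as an estimate. For compound 4 the estimated value is 200 nM with an expected range from 90 nM to 450 nM in this assay.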

Compound 4, half-maximal inhibitory concentration: 50 nM
Beside the measured number, compound 4's estimate is 4.0-fold (0.60 log units) above it; measured number outside the range, below it.
By their numbers in this assay, from the lowest: compounds 4, 2, 1 and 3 (each within the scatter of the next, the first and the last beyond it).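

In this assay the step is a 2.0-fold lower number from compound 1 to compound 4 (0.30 log units; within the scatter) and so, with 3,4-difluorophenyl on the ring, methylcarbamoyl and 1,2-dihydroxyethyl cannot be told apart at this place, even though the entering group has 1 hydrogen-bond donor and 1 hydrogen-bond acceptor where the leaving group has 2 of each. For the compounds shown here, the only earlier change at this place was a 2.3-fold higher number from compound 2 to compound 3 (0.36 log units; beyond the scatter) and that step lay beyond the scatter, so the new result shows that an amide here need not bring such a rise and that the 1,2-dihydroxyethyl group is not required for a number in this range. Nothing available explains why the two amide steps read differently.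

Two matched compounds would separate the roles of the methyl and the ring substituents: carbamoyl with 3,4-difluorophenyl, and methylcarbamoyl with 3,4-dichlorophenyl. Going by these compounds, it also remains open how far this place accepts other groups, such as dimethylcarbamoyl, a carboxylic acid, an amine or a longer chain ending in methylcarbamoyl.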